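Adding a hydroxy group to compound 2

This account rests on a few compounds, and the source may have more. Where it says the series, first, only, none or still open, it means among the compounds named here.

Compound 1 `CC(=O)Nc1ccc2oc(-c3ccccc3)cc(=O)c2c1` gives 97000 nM
Compound 2 `CC(=O)Nc1ccc2oc(-c3ccc(C(F)(F)F)cc3)cc(=O)c2c1` gives 10000 nM
Compound 3 `Nc1ccc2oc(-c3ccc(C(F)(F)F)cc3)cc(=O)c2c1` gives 1900 nM

In an ADME assay on THP-1 cells (Homo sapiens) for cytotoxicity, read by flow cytometry and propidium iodide staining, with a stated time of 72 h (on this read-out higher numbers stand for weaker inhibition and lower numbers for stronger inhibition), compound 2 holds the middle of the three numbers. Compound 4 `CC(=O)Nc1ccc2oc(-c3ccc(C(F)(F)F)cc3)c(O)c(=O)c2c1` has not been measured yet. It differs from compound 2 by one change: hydroxy in place of hydrogen on an aromatic carbon. Among the compounds with values here, no measured step involves this place, so the guidance is indirect. The two nearest steps are a 9.7-fold lower number from compound 1 to compound 2 (0.99 log units; beyond the scatter) and a 5.3-fold lower number from compound 2 to compound 3 (0.72 log units; beyond the scatter), both modest and both towards lower numbers. A modest step is therefore expected here too, tentatively in the same direction. The expected size is a 1.7-fold lower number from compound 2 to compound 4 (0.22 log units; within the scatter). For compound 4 the estimated value is 6000 nM, with an expected range from 1500 nM to 20000 nM.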

Compound 4, half-maximal inhibitory concentration: > 50000 nM
Compound 4 ended at the assay's limit; the forecaster's own chance of this, stated with the estimate: 5%; at least 8.3-fold (0.92 log units) between middle value and limit.
By their numbers in this assay, from the lowest: compound 3; then compound 2; then compound 1.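

In this assay, both earlier steps went towards lower numbers, whereas hydroxy in place of hydrogen on this aromatic carbon, two atoms from the ring oxygen, gives an at least 5.0-fold higher number from compound 2 to compound 4 (0.69 log units; beyond the scatter). This is the first change shown that weakens inhibition, and the first at this position on the shared core. Compound 4 stands at a limit, not at a number: the limit of > 50000 nM in this assay, at which 1 of the 4 values shown sits.

On these data alone, whether a methoxy group or a single fluorine atom on the same carbon would move the number the same way stays open. So does the effect of hydroxy here on compound 3.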